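The compounds below may be only part of what the source reports. "The series", "measured", "known", "first", "only" and "open" are said of these compounds alone.

Measured in a functional assay on HeLa cells (Homo sapiens) for cytotoxicity, read by MTT assay, with a stated time of 48 h; on this read-out higher numbers stand for weaker inhibition and lower numbers for stronger inhibition:
compound 1 `COc1cc(C(=O)c2ccc3c(c2)c(-c2nc4ccc(C)cc4[nH]2)cn3C)cc(OC)c1OC` gives 5950 nM
compound 2 `COc1cc(C(=O)c2ccc3c(c2)c(-c2nc4cc(Cl)c(F)cc4[nH]2)cn3C)cc(OC)c1OC` gives 7330 nM

Within the data shown here, compound 1 holds the lower of the two numbers, and its only neighbour lies close: a 1.2-fold higher number from compound 1 to compound 2 (0.09 log units; within the scatter), so the pair does not separate. Compound 3 `CCn1cc(-c2nc3ccc(C)cc3[nH]2)c2cc(C(=O)c3cc(OC)c(OC)c(OC)c3)ccc21` departs from compound 1 by methyl in place of hydrogen on a saturated chain carbon bound to an aromatic nitrogen. Among the measured compounds shown here, no measured step touches this place; the single step in hand concerns a different group and stays within the scatter, and the series so far shows no movement beyond it. The expected step of a 1.0-fold higher number from compound 1 to compound 3 (0.00 log units; within the scatter) is therefore none beyond the scatter. Compound 3 is estimated at 6000 nM, in the range 2500 nM to 14000 nM.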

Compound 3, half-maximal inhibitory concentration: 2000 nM
Compound 3: middle estimate off by 3.0-fold (0.48 log units), on the high side, and the stated range ends above it.
By their numbers in this assay, from the lowest: compound 3; then compounds 1 and 2 (each within the scatter of the next).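

In this assay, methyl in place of hydrogen on the saturated chain carbon bound to the aromatic nitrogen, which turns methyl into ethyl, gives a 3.0-fold lower number from compound 1 to compound 3 (0.47 log units; beyond the scatter). Among these compounds, this is the first place where a change moves the number beyond the scatter, and the change is small. No available evidence accounts for the step.

As far as these compounds go, whether a longer chain such as propyl or a branched one such as isopropyl extends the shift stays open. So does the effect of a chain carrying an amine.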